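Trimming a Pentyl Chain: Expected Effect on Growth Inhibition

A few compounds are considered here, and "the series" means these few. Any claim that something is new, unique, unknown or untested is made for them only; others in the source may bear on it.

Measured compounds:
compound 1 `CCCCCc1cc2c(=O)n(CCCSc3nc(-c4cc(OC)c(OC)c(OC)c4)c(C#N)c(=O)[nH]3)cnc2s1`, 72.8 ug/mL
compound 2 `N#Cc1c(-c2ccc(O)cc2)[nH]c(=S)[nH]c1=O`, 89.1 ug/mL
compound 3 `CCCCCCCc1cc2c(=O)n(CCSc3nc(-c4cc(OC)c(OC)c(OC)c4)c(C#N)c(=O)[nH]3)cnc2s1`, 72.6 ug/mL

In an ADME assay on PANC-1 cells (Homo sapiens) for inhibition, read by MTT assay (a higher number here means a weaker inhibitor of growth, a lower number a stronger inhibitor of growth), compound 1 gives 72.8 ug/mL and stands second highest of the three numbers. Compound 3 gives 72.6 ug/mL, within the scatter of compound 1, and compound 2 gives 89.1 ug/mL, also within the scatter, so the three values cannot be told apart in this assay. Compound 4 `CCCc1cc2c(=O)n(CCCSc3nc(-c4cc(OC)c(OC)c(OC)c4)c(C#N)c(=O)[nH]3)cnc2s1` differs from compound 1 by hydrogen in place of ethyl on a saturated chain carbon, three bonds along the chain from an aromatic carbon. Among the compounds with values here, no step between measured compounds informs this change, and the measured values give no sign of any difference larger than the scatter. For compound 4 the step of a 1.0-fold higher number from compound 1 to compound 4 (0.01 log units; within the scatter) is expected to be no larger than the scatter. Compound 4 is therefore estimated at 75 ug/mL in this assay, ranging from 40 ug/mL to 140 ug/mL.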

Compound 4, concentration for 50% growth inhibition: > 100 ug/mL
Compound 4 was reported as a limit (the forecaster's own chance of this, stated with the estimate: 10%); middle value at least 1.3-fold (0.12 log units) away from the limit.
By their numbers in this assay, from the lowest: compounds 3, 1 and 2 (each within the scatter of the next). At a limit, above all of these: compound 4.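

Compound 4 reads as a limit in this assay, not as a number: the limit of > 100 ug/mL in this assay, at which 1 of the 4 values shown sits. Trimming pentyl to propyl on this chain gives an at least 1.3-fold higher number from compound 1 to compound 4 (0.13 log units; that floor lies within the scatter), the first step in this set that can be read at all. It points towards a weaker inhibitor of growth, but only the floor of the step is known, so this position cannot yet be called sensitive to the change. The compounds shown leave open how large the step truly is. They also leave open whether a butyl chain, a longer chain or a chain ending in an amine would read differently here.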